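The compounds below may be only part of what the source reports. "The series", "measured", "known", "first", "only" and "open" are said of these compounds alone.

Compounds measured in an ADME assay on microsomes from liver (Homo sapiens) for metabolic stability; a lower number here means slower removal, a higher number faster removal of the compound:
compound 1, `O=C(N[C@H]1CCC[C@H](CO)C1)C1CCN(c2nc3cc(Cl)c(Cl)cc3o2)CC1`, gives 27.1 mL/min/kg
compound 2, `O=C(N[C@H]1CCC[C@H](CO)C1)C1CCN(c2nc3cc(Cl)c(-c4ccc(F)cc4)cc3o2)CC1`, gives 81.9 mL/min/kg
compound 3, `O=C(N[C@H]1CCC[C@H](CO)C1)C1CCN(c2nc3cc(Cl)c(-c4cccc(Cl)c4)cc3o2)CC1`, gives 55.8 mL/min/kg

Compound 3 stands second highest of the three numbers. Its nearest neighbour is compound 2, separated by a 1.5-fold lower number from compound 2 to compound 3 (0.17 log units; within the scatter), a gap within the scatter; furthest away is compound 1, with a 2.1-fold higher number from compound 1 to compound 3 (0.31 log units; beyond the scatter), beyond the scatter. Compound 4, `CCOc1ccc(-c2cc3oc(N4CCC(C(=O)N[C@H]5CCC[C@H](CO)C5)CC4)nc3cc2Cl)cc1`, differs from compound 3 in one place: 4-ethoxyphenyl in place of 3-chlorophenyl on an aromatic carbon. Going by the values given here, the steps that bear on this change are those that place an aryl group on the same carbon, a 3.0-fold higher number from compound 1 to compound 2 (0.48 log units; beyond the scatter) and a 2.1-fold higher number from compound 1 to compound 3 (0.31 log units; beyond the scatter), both modest rises beyond the scatter, and the exchange of one aryl for another, a 1.5-fold lower number from compound 2 to compound 3 (0.17 log units; within the scatter), which stays within the scatter. Among the compounds with values here, no measured compound carries an ethoxyphenyl group, so the data give no direct guide to that part of the change. Due to a 1.5-fold lower number from compound 2 to compound 3 (0.17 log units; within the scatter), swapping one aryl for another is expected to move the number little, so compound 4 is expected to show a 1.3-fold higher number from compound 3 to compound 4 (0.13 log units; within the scatter), a step likely within the scatter. The estimate for compound 4 is 75 mL/min/kg, with a range from 40 mL/min/kg to 140 mL/min/kg.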

Compound 4, clearance: < 8 mL/min/kg
Compound 4: only a limit was reported; the forecaster's own chance of this, stated with the estimate: 5%; middle value at least 9.3-fold (0.97 log units) from the limit.
By their numbers in this assay, from the lowest: compound 1; then compounds 3 and 2 (each within the scatter of the next). At a limit, below all of these: compound 4.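

Compound 4 is reported in this assay only as a limit: the limit of < 8 mL/min/kg in this assay, at which 1 of the 4 values shown sits. On this aromatic carbon, ortho to a chloro group, the identity of the aryl group matters far more than the close values of compound 2 and compound 3 had suggested, with 4-ethoxyphenyl giving an at least 6.9-fold lower number from compound 3 to compound 4 (0.84 log units; beyond the scatter), and ethoxy in place of fluoro giving an at least 10-fold lower number from compound 2 to compound 4 (1.01 log units; beyond the scatter). Replacing chloro with an aryl group had raised the number in compound 2 and compound 3, but here it gives an at least 3.3-fold lower number from compound 1 to compound 4 (0.52 log units; beyond the scatter), so an aryl group on this carbon does not in itself raise the number.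

The compounds shown leave open how far the number lies beneath the limit. They also leave open whether a methoxy group, a longer alkoxy chain or ethoxy elsewhere on the phenyl ring would give the same result.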